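Swapping the propargyl arm for benzyl on a protected sugar

The source may report more compounds than this note shows. Statements on the series, on what has been measured and on what is new or still open speak of the compounds shown alone.

Compound 1 `C#CC[C@@H]1O[C@H](COCc2ccccc2)[C@@H](OCc2ccccc2)[C@H](OCc2ccccc2)[C@H]1O` carries three benzyl-protected hydroxyl groups on a saturated ring and a short propargyl arm. In a functional assay on HL-60 cells (Homo sapiens) for antiproliferative activity, read by MTT assay (a lower number here means a stronger inhibitor, a higher number a weaker inhibitor), compound 1 gives "not active" (no number reported); no number stands beside it. The same picture holds for compound 3 `C=C[C@H]1O[C@H](COCc2ccccc2)[C@@H](OCc2ccccc2)[C@H](OCc2ccccc2)[C@H]1OC(C)=O`, which in this assay gives "not active" (no number reported). Among the measured compounds shown here, the only compound of the set with a number is compound 2 `ClC1(Cl)[C@@H]2[C@@H](OCc3ccccc3)[C@H](OCc3ccccc3)[C@@H](COCc3ccccc3)O[C@@H]21`, which in this assay gives 46400 nM, a weak result. Compound 1 therefore stands among the weakest of the shown compounds, with nothing to rank it against compound 3.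

Compound 4 `O[C@@H]1[C@@H](OCc2ccccc2)[C@H](OCc2ccccc2)[C@@H](COCc2ccccc2)O[C@H]1Cc1ccccc1` differs from compound 1 in one place: phenyl in place of ethynyl on a saturated chain carbon bound to a saturated ring carbon. For the measured compounds named here, no measured pair shows this change, so the size of the step in this assay is open; with compound 1 and compound 3 both recorded as inactive and compound 2 only weakly active, no shift beyond the scatter toward stronger inhibition is expected. The value of compound 4 in this assay is estimated at 50000 nM, within 15000 nM to 150000 nM.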

Compound 4, half-maximal inhibitory concentration: 8700 nM
Beside the measured number, compound 4's estimate is 5.7-fold (0.76 log units) above it; the measured number lies below the stated range.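

No step can be read from compound 1 to compound 4, as compound 1 has no number to set against that of compound 4. The compounds shown leave open how large the change from propargyl to benzyl is. Nothing measured here accounts for the result.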